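Swapping the aryl on the carbonyl of compound 1

A few compounds are considered here, and "the series" means these few. Any claim that something is new, unique, unknown or untested is made for them only; others in the source may bear on it.

Three quinazoline-based thiosemicarbazide compounds were examined in a functional assay on GLC82 cells (Homo sapiens) for cytotoxicity, read by MTT assay, with a stated time of 72 h; a lower number here means a stronger inhibitor, a higher number a weaker inhibitor. Compound 1 `COc1cc2ncnc(NNC(=S)NC(=O)c3ccc(C(F)(F)F)cc3)c2cc1OC` gives 16500 nM and stands highest of the three numbers. Its nearest neighbour, compound 2 `Cc1ccc(C(=O)NC(=S)NNc2ncnc3ccccc23)cc1`, gives 11200 nM, a difference within the usual scatter, so the two cannot be ordered. Compound 3 `O=C(NC(=S)NNc1ncnc2ccccc12)c1cccc(Cl)c1` gives 3240 nM, the furthest from compound 1 and beyond the scatter. For the measured compounds named here, the only single-point step among the measured compounds is a 3.5-fold lower number from compound 2 to compound 3 (0.54 log units; beyond the scatter), a modest change. That step also alters the aryl attached to the carbonyl carbon, and so it bears on the new compound.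

Compound 4 `COc1cc2ncnc(NNC(=S)NC(=O)c3ccccc3Cl)c2cc1OC` is drawn from compound 1 by the change (2-chlorophenyl in place of 4-(trifluoromethyl)phenyl on a carbonyl carbon), keeping the shared core of compound 1. The measured step from compound 2 to compound 3 suggests that a chlorophenyl in this position can bring the number down, though there the chlorine sat on 3-chlorophenyl and the core lacked the two methoxy groups, so the transfer is uncertain. The expectation is therefore a modest lowering, estimated as a 2.4-fold lower number from compound 1 to compound 4 (0.37 log units; beyond the scatter). Compound 4 is accordingly expected to give about 7000 nM in this assay, within a range from 2500 nM to 20000 nM.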

Compound 4, half-maximal inhibitory concentration: 10000 nM
For compound 4 the middle estimate is 1.4-fold (0.15 log units) below the measured one; the measured number falls inside the stated range.
By their numbers in this assay, from the lowest: compound 3; then compounds 4, 2 and 1 (each within the scatter of the next).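

In this assay, putting 2-chlorophenyl in place of 4-(trifluoromethyl)phenyl on a carbonyl carbon gives a 1.7-fold lower number from compound 1 to compound 4 (0.22 log units; within the scatter), so on the shared core of compound 1 these two aryl groups cannot be told apart. For the compounds shown here, until now, the only exchange at this place was on the core without the two methoxy groups, a 3.5-fold lower number from compound 2 to compound 3 (0.54 log units; beyond the scatter); the new pair is the first on the dimethoxy core, and it shows that a chlorophenyl at this place does not always bring a change beyond the scatter. Nothing available here gives a measured reason for this result.

The compounds shown leave open whether 3-chlorophenyl would give a step beyond the scatter on the core of compound 1, and no pair isolates the two methoxy groups, so their part in these numbers cannot be read. Also open, from the compounds shown here alone, is how the number would respond if the aryl on the carbonyl carbon carried an amine or a carboxylic acid, or if a longer alkyl chain replaced that aryl.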